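Exchanging the sulfonyl aryl group of compound 3

The source may hold more compounds than are shown below. What is called first, only, known or untested is meant among the compounds shown, and "the series" means these compounds.

Measured in a functional assay on A549 cells (Homo sapiens) for antiproliferative activity, read by MTT assay, with a stated time of 24 h; a higher number here means a weaker inhibitor, a lower number a stronger inhibitor:
Compound 1 `Cc1ccc(-c2nn(-c3ccccc3)cc2-c2nc3ccccc3n2S(=O)(=O)c2ccc(Cl)cc2)cc1`: 3550 nM
Compound 2 `O=S(=O)(c1ccccc1)n1c(-c2cn(-c3ccccc3)nc2-c2ccc(C(F)(F)F)cc2)nc2ccccc21`: 480 nM
Compound 3 `Cc1ccc(C)c(S(=O)(=O)n2c(-c3cn(-c4ccccc4)nc3-c3ccc(C(F)(F)F)cc3)nc3ccccc32)c1`: 150 nM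

Compound 3 has the lowest of these three numbers, and compound 2 lies nearest to it. Compound 4 `O=S(=O)(c1ccc(Cl)cc1)n1c(-c2cn(-c3ccccc3)nc2-c2ccc(C(F)(F)F)cc2)nc2ccccc21` differs from compound 3 as follows: 4-chlorophenyl in place of 2,5-dimethylphenyl on a sulfonyl sulfur. Among the compounds with values here, the only measured step at this place is a 3.2-fold lower number from compound 2 to compound 3 (0.51 log units; beyond the scatter), with 2,5-dimethylphenyl in place of phenyl. Within the data shown here, compound 1 also carries 4-chlorophenyl on a sulfonyl sulfur but differs elsewhere too, and offers no direct step. A modest move to a higher number is therefore expected in this assay, and the expected step is a 2.3-fold higher number from compound 3 to compound 4 (0.37 log units; beyond the scatter). Compound 4 is estimated at 350 nM, within an expected range of 110 nM to 1200 nM.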

Compound 4, half-maximal inhibitory concentration: 2560 nM
Estimate against measurement, compound 4: 7.3-fold (0.86 log units) below; measured number above the stated range.
By their numbers in this assay, from the lowest: compound 3; then compound 2; then compounds 4 and 1 (each within the scatter of the next).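

In this assay, within the data shown here, the aryl group on the sulfonyl sulfur proves more decisive than the one earlier step showed: 4-chlorophenyl in place of 2,5-dimethylphenyl gives a 17-fold higher number from compound 3 to compound 4 (1.23 log units; beyond the scatter) and chloro in place of hydrogen on an aromatic carbon gives a 5.3-fold higher number from compound 2 to compound 4 (0.73 log units; beyond the scatter) as well. With 4-chlorophenyl held on the sulfonyl sulfur, trifluoromethyl in place of methyl gives a 1.4-fold lower number from compound 1 to compound 4 (0.14 log units; within the scatter) and so does not separate those two compounds. No measured evidence accounts for these steps. Still open, as far as these compounds go, is whether a methoxy group or an amine on the sulfonyl phenyl ring would hold the number of compound 3, and whether a single methyl group would do so.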